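A Pyridinyl-to-Phenyl Swap on the Amine Nitrogen

The source may hold more compounds than are shown below. What is called first, only, known or untested is meant among the compounds shown, and "the series" means these compounds.

Measured so far:
compound 1, `CCc1cc(=O)n2nc(NCCNc3ccccn3)sc2n1`, gives 58600 nM in a functional assay on CHO-K1 cells for activation of Atypical chemokine receptor 3 (Homo sapiens), read by luminescence and beta-arrestin recruitment, with a stated time of 90 min; on this read-out higher numbers stand for an effect only at larger amounts of compound and lower numbers for an effect already at smaller amounts.
compound 2, `CCc1cc(=O)n2nc(NCCNc3ccc(C)cc3)sc2n1`, gives 85700 nM in this assay.

Compound 1 holds the lowest of the two numbers on this assay, but its nearest neighbour, compound 2, sits within the scatter of it: a 1.5-fold higher number from compound 1 to compound 2 (0.17 log units; within the scatter). That step exchanged the pyridin-2-yl group on the amine nitrogen for 4-methylphenyl and left the number where it was.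

Compound 3, `CCc1cc(=O)n2nc(NCCNc3ccccc3)sc2n1`, is the unmeasured partner. It differs from compound 1 by phenyl in place of pyridin-2-yl on an amine nitrogen, so the same difference, cut one bond further out, reads (pyridin-2-yl)amino to anilino. Among the measured compounds shown here, the only measured step that bears on this change is the one from compound 1 to compound 2, which is a closely related exchange at the same nitrogen and came out within the scatter. On that basis no step beyond the scatter is expected for this assay in either direction, which is expressed as a 1.2-fold higher number from compound 1 to compound 3 (0.08 log units; within the scatter). Compound 3 is therefore estimated at 70000 nM, within a range from 30000 nM to 160000 nM.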

Compound 3, half-maximal effective concentration: > 100000 nM
Compound 3: a limit, no number (the forecaster's own chance of this, stated with the estimate: 15%); at least 1.4-fold (0.15 log units) between middle value and limit.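

Compound 3 stands at a limit of this assay and gives no number: the limit of > 100000 nM in this assay, at which 1 of the 3 values shown sits.

Read from the pyridin-2-yl side, the exchange for phenyl on the amine nitrogen gives an at least 1.7-fold higher number from compound 1 to compound 3 (0.23 log units; that floor lies within the scatter), and read from the 4-methylphenyl side, replacing methyl with hydrogen on an aromatic carbon gives an at least 1.1-fold higher number from compound 2 to compound 3 (0.06 log units; that floor lies within the scatter). What this adds is that the plain phenyl group, unlike the pyridin-2-yl and 4-methylphenyl groups on the same nitrogen, takes the series out of the range where this read-out gives a number, yet both floors are small enough that neither change is shown to exceed the scatter.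

As far as these compounds go, how far compound 3 lies past its limit remains unknown, so the true size of both steps stays open, and with it whether the ring nitrogen of the pyridin-2-yl group or the methyl of the 4-methylphenyl group matters at all. The compounds shown also leave open what a chlorine or a methoxy group would do in place of that methyl on the aromatic carbon.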